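Swapping thiophene for benzofuran on a nucleoside

The source may report more compounds than this note shows. Statements on the series, on what has been measured and on what is new or still open speak of the compounds shown alone.

Compound 1 `CNc1ncnc2c1c(-c1cc3ccccc3o1)cn2[C@@H]1O[C@H](CO)[C@@H](O)[C@H]1O`: 75600 nM
Compound 2 `Cc1ncnc2c1c(-c1cccs1)cn2[C@@H]1O[C@H](CO)[C@@H](O)[C@H]1O`: > 100000 nM (a limit)

In an ADME assay on BJ cells (Homo sapiens), read by MTT assay, with a stated time of 72 h (on this read-out higher numbers stand for weaker inhibition and lower numbers for stronger inhibition), compound 2 gives no number, only the limit > 100000 nM.

Compound 3 `Cc1ncnc2c1c(-c1cc3ccccc3o1)cn2[C@@H]1O[C@H](CO)[C@@H](O)[C@H]1O` differs from compound 2 by one change on an aromatic carbon: 1-benzofuran-2-yl in place of thiophen-2-yl on an aromatic carbon. Among the compounds with values here, no measured pair shows this change directly. Because compound 1 with 1-benzofuran-2-yl gives 75600 nM a modest shift towards stronger inhibition is expected. The expected step is an at least 1.6-fold lower number from compound 2 to compound 3 (0.22 log units; that floor lies within the scatter). For compound 3 the estimated value is 60000 nM, with an expected range of 20000 nM to 100000 nM.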

Compound 3, half-maximal inhibitory concentration: 93900 nM
Compound 3: the middle estimate sits 1.6-fold (0.19 log units) below what was measured; low and high end bracket the measured number.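

In this assay, placing 1-benzofuran-2-yl on this aromatic carbon gives only a floor for the step, an at least 1.0-fold lower number from compound 2 to compound 3 (0.02 log units; that floor lies within the scatter), so the change from thiophen-2-yl has no firm size. Compound 2 is held at a limit, not a number: the limit of > 100000 nM in this assay, at which 1 of the 3 values shown sits.

With 1-benzofuran-2-yl kept in place, methyl in place of methylamino gives a 1.2-fold higher number from compound 1 to compound 3 (0.09 log units; within the scatter).

The compounds shown leave open how a carboxylic acid on the 1-benzofuran-2-yl group would read in this assay. They also leave open what a longer chain in place of methyl would give.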